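Aryl amine variation on the shared core: fluoropyridyl step

A few compounds are considered here, and "the series" means these few. Any claim that something is new, unique, unknown or untested is made for them only; others in the source may bear on it.

Measured in a functional assay on SK-HEP1 cells (Homo sapiens) for cytotoxicity, read by sulforhodamine B assay, with a stated time of 72 h; on this read-out lower numbers stand for stronger inhibition and higher numbers for weaker inhibition:
compound 1 `CCS(=O)(=O)Nc1cc(-c2ccc3ncnc(Nc4ccc(F)cc4F)c3c2)cnc1OC` gives 2490 nM
compound 2 `CCS(=O)(=O)Nc1cc(-c2ccc3ncnc(Nc4cccc(C(=O)OC)c4)c3c2)cnc1OC` gives 2400 nM
compound 3 `CCS(=O)(=O)Nc1cc(-c2ccc3ncnc(Nc4ccc(C(=O)OC)c(OC)c4)c3c2)cnc1OC` gives 830 nM

Compound 3 holds the lowest number of the three in this assay. Its nearest neighbour is compound 2, with a 2.9-fold lower number from compound 2 to compound 3 (0.46 log units; beyond the scatter); the furthest is compound 1, with a 3.0-fold lower number from compound 1 to compound 3 (0.48 log units; beyond the scatter). Compound 1 and compound 2 lie within the scatter of each other: a 1.0-fold lower number from compound 1 to compound 2 (0.02 log units; within the scatter).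

Compound 4 `CCS(=O)(=O)Nc1cc(-c2ccc3ncnc(Nc4ccc(F)nc4)c3c2)cnc1OC` is not yet measured. The change from compound 3 is 6-fluoropyridin-3-yl in place of 3-methoxy-4-(methoxycarbonyl)phenyl on a nitrogen on an aromatic ring. Going by the values given here, the steps that bear on it are the two into compound 3, both modest and both gained on introducing the 3-methoxy-4-(methoxycarbonyl)phenyl group; compound 4 gives that group up for a ring carrying fluorine on the nitrogen, as compound 1 has, so the step is read in reverse. In this assay compound 4 is therefore expected to return toward the numbers of compound 1 and compound 2, an expected step of a 2.7-fold higher number from compound 3 to compound 4 (0.42 log units; beyond the scatter). The estimate for compound 4 in this assay is 2200 nM, with a range from 700 nM to 7000 nM.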

Compound 4, half-maximal inhibitory concentration: 5240 nM
The estimate for compound 4 lay 2.4-fold (0.38 log units) below the measured number; measured number inside the range.
By their numbers in this assay, from the lowest: compound 3; then compounds 2 and 1 (each within the scatter of the next); then compound 4.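

In this assay, going by these compounds alone, this position has more range on the high side than the earlier compounds showed: a 6.3-fold higher number from compound 3 to compound 4 (0.80 log units; beyond the scatter) is the largest step in the set so far, and 6-fluoropyridin-3-yl also stands apart from the two earlier groups, with a 2.2-fold higher number from compound 2 to compound 4 (0.34 log units; beyond the scatter) and a 2.1-fold higher number from compound 1 to compound 4 (0.32 log units; beyond the scatter) all beyond the scatter. Compound 1 and compound 2 therefore do not mark the upper end for aryl groups on this nitrogen, and a fluorine-bearing ring with a hetero atom gives the highest number of the four. No measured finding bears on why the number rises with this change.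

Open, on these data alone, is whether pyridin-3-yl without fluorine would sit with compound 4 or closer to compound 2. Also open, as far as these compounds go, is whether a carboxylic acid in place of the methyl ester would keep the low number of compound 3.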